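A few compounds are considered here, and "the series" means these few. Any claim that something is new, unique, unknown or untested is made for them only; others in the source may bear on it.

Compound 1 `COc1ccc(Nc2cc(C)nc(SCc3nc4ccccc4[nH]3)n2)cc1` gives 67400 nM in a functional assay on PC-3 cells (Homo sapiens) for cytotoxicity, read by MTT assay, with a stated time of 72 h; a lower number here means a stronger inhibitor, a higher number a weaker inhibitor.
Compound 2 `Cc1cc(NCCO)nc(SCc2nc3ccccc3[nH]2)n1` reaches only a limit of the assay, > 100000 nM.
Compound 3 `Cc1cc(Nc2ccc(Br)cc2)nc(SCc2nc3ccccc3[nH]2)n1` gives 37100 nM.

All three share one core and differ only in the group on the amine nitrogen. Compound 1 gives the higher of the two numbers available; the step of a 1.8-fold lower number from compound 1 to compound 3 (0.26 log units; within the scatter) lies within the scatter, so the two cannot be ranked. Compound 4 `Cc1cc(N(C)Cc2ccccc2)nc(SCc2nc3ccccc3[nH]2)n1` has not yet been measured. It differs from compound 1 by benzyl(methyl)amino in place of (4-methoxyphenyl)amino on an aromatic carbon. Going by the values given here, two measured steps bear on this change. Removing the aromatic ring from that nitrogen gave an at least 1.4-fold higher number from compound 1 to compound 2 (0.17 log units; that floor lies within the scatter), reaching the limit, while bringing an aromatic ring back gave an at least 2.6-fold lower number from compound 2 to compound 3 (0.43 log units; beyond the scatter). Compound 4 keeps a six-membered aromatic ring of carbon only on that nitrogen, though now as benzyl with a methyl in place of the hydrogen-bond donor. An expected step of a 1.0-fold higher number from compound 1 to compound 4 (0.02 log units; within the scatter) is therefore modest and may well stay within the scatter. Compound 4 is thus estimated at 70000 nM, with an expected range from 30000 nM to 160000 nM.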

Compound 4, half-maximal inhibitory concentration: > 100000 nM
Compound 4: no number, only a limit; the forecaster's own chance of this, stated with the estimate: 25%; at least 1.4-fold (0.15 log units) between middle value and limit.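

Benzyl(methyl)amino carries a six-membered aromatic ring of carbon only, as (4-bromophenyl)amino does, yet this swap gives an at least 2.6-fold higher number from compound 3 to compound 4 (0.43 log units; beyond the scatter), so such a ring on this position is not enough to keep a measurable number. The comparison with the methoxy analogue is less firm: an at least 1.4-fold higher number from compound 1 to compound 4 (0.17 log units; that floor lies within the scatter), and that floor alone does not separate the two compounds. Compound 2 and compound 4 both end at a limit, so the step between them cannot be read, and this small set now shows that limit more than once: the limit of > 100000 nM in this assay, at which 2 of the 4 values shown sit.

The change from compound 1 to compound 4 both adds a carbon link before the ring and replaces the hydrogen on the nitrogen with a methyl, and the compounds shown do not separate these two changes. Open too, on these data alone, is how benzylamino, which keeps that hydrogen, or N-methylanilino, which keeps the ring directly on the nitrogen, would behave at this position.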